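A few compounds are considered here, and "the series" means these few. Any claim that something is new, unique, unknown or untested is made for them only; others in the source may bear on it.

Measured compounds:
compound 1, `Cc1nc(N(C)C(=O)NC(=O)c2c(F)cccc2F)sc1C(=O)N/N=C/c1cccc(C(F)(F)F)c1`, 32.7 ug/mL in a functional assay on BCG823 cells (Homo sapiens) for inhibition, read by MTT assay, with a stated time of 72 h; a lower number here means a stronger inhibitor, a higher number a weaker inhibitor
compound 2, `Cc1nc(N(C)C(=O)NC(=O)c2ccc(Cl)cc2Cl)sc1C(=O)N/N=C/c1ccc(C(F)(F)F)cc1`, 38 ug/mL
compound 3, `CN(C(=O)NC(=O)c1c(F)cccc1F)c1nc(C(F)(F)F)c(C(=O)N/N=C/c2ccc(C(F)(F)F)cc2)s1`, 34.9 ug/mL

The three numbers sit close together: compound 3 has the second highest of the three, with compound 1 nearest and compound 2 furthest, and both gaps are within the scatter, so no order among them can be read.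

Compound 4, `Cc1nc(N(C)C(=O)NC(=O)c2c(F)cccc2F)sc1C(=O)N/N=C/c1ccc(C(F)(F)F)cc1`, is not yet measured. Against compound 3 the change is methyl in place of trifluoromethyl on an aromatic carbon. For the measured compounds named here, with no measured pair differing in that one place, nothing on this series shows what the swap does; the expectation is a step from compound 3 to compound 4 of a 1.0-fold lower number from compound 3 to compound 4 (0.01 log units; within the scatter), that is, none beyond the scatter.

Compound 4 is therefore expected to give about 34 ug/mL, within 17 ug/mL to 70 ug/mL.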

Compound 4, half-maximal inhibitory concentration: 65.5 ug/mL
Compound 4: the middle estimate sits 1.9-fold (0.28 log units) below what was measured; the range from low to high includes it.
By their numbers in this assay, from the lowest: compounds 1, 3, 2 and 4 (each within the scatter of the next).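

In this assay, for the compounds shown here, the series now has a first reading at this position: the step of a 1.9-fold higher number from compound 3 to compound 4 (0.27 log units; within the scatter) comes with methyl in place of trifluoromethyl on an aromatic carbon next to the ring nitrogen. The two other single-place steps are also printed as within the scatter: 2,6-difluorophenyl in place of 2,4-dichlorophenyl (a 1.7-fold higher number from compound 2 to compound 4 (0.24 log units; within the scatter)) and 4-(trifluoromethyl)phenyl in place of 3-(trifluoromethyl)phenyl (a 2.0-fold higher number from compound 1 to compound 4 (0.30 log units; within the scatter)). Nothing available explains these steps.

Open, as far as these compounds go, is whether an amine or an ethyl group on this aromatic carbon would give a step beyond the scatter.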